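The compounds below may be only part of what the source reports. "The series", "measured", "known", "first", "only" and "open" are said of these compounds alone.

Measured in a functional assay on KB cells (Homo sapiens) for antiproliferative activity, read by sulforhodamine B assay, with a stated time of 3 days; on this read-out higher numbers stand for an effect only at larger amounts of compound and lower numbers for an effect already at smaller amounts:
- Compound 1 `CCC1=C(O)c2c(oc(-c3ccc(COC)cc3)cc2=O)C(CC)(CC)C1=O`: > 52.4 uM (a limit)
- Compound 2 `CCC1=C(O)c2c(oc(-c3cccc(OC)c3)cc2=O)C(CC)(CC)C1=O`: 13.3 uM
- Compound 3 `CCC1=C(O)c2c(oc(-c3ccc(OC)c(C)c3)cc2=O)C(CC)(CC)C1=O`: 28.5 uM

Of the two actual numbers, compound 2 has the lower. Compound 4 `CCC1=C(O)c2c(oc(-c3cc(OC)ccc3OC)cc2=O)C(CC)(CC)C1=O` carries one change from compound 2: methoxy in place of hydrogen on an aromatic carbon, with methoxy in place of hydrogen on an aromatic carbon, ortho to a large group and para to a methoxy group. For the measured compounds named here, no measured step makes this exact change. The nearest guide is a 2.1-fold higher number from compound 2 to compound 3 (0.33 log units; beyond the scatter), with 4-methoxy-3-methylphenyl in place of 3-methoxyphenyl. Also relevant is an at least 3.9-fold lower number from compound 1 to compound 2 (0.59 log units; beyond the scatter), which rests on a limit. In this assay, a modest rise is therefore expected, a 1.5-fold higher number from compound 2 to compound 4 (0.18 log units; within the scatter). For compound 4 the estimate is 20 uM, with an expected range from 8 uM to 50 uM.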

Compound 4, concentration for half-maximal effect: 8.8 uM
Compound 4: the middle estimate sits 2.3-fold (0.36 log units) above what was measured, within the range that was stated.
By their numbers in this assay, from the lowest: compounds 4 and 2 (each within the scatter of the next); then compound 3. At a limit, above all of these: compound 1.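

In this assay, methoxy in place of hydrogen on this aromatic carbon, ortho to a large group and para to a methoxy group, gives a 1.5-fold lower number from compound 2 to compound 4 (0.18 log units; within the scatter), so the added group costs nothing that can be read at this place. The earlier change on this aryl ring, by contrast, gave a 2.1-fold higher number from compound 2 to compound 3 (0.33 log units; beyond the scatter). Nothing measured here gives a cause for this result.

On these data alone, whether an amine, a carboxylic acid or a longer chain such as ethoxy would be accepted at this position stays open. So does whether any group here would bring a step beyond the scatter.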